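Chloro to bromo on the phenyl ring of compound 3

The compounds below may be only part of what the source reports. "The series", "measured", "known", "first", "only" and "open" are said of these compounds alone.

Measured so far in a functional assay on SNB-19 cells (Homo sapiens) for inhibition, read by sulforhodamine B assay, with a stated time of 48 h, tested at 10 uM; on this read-out lower numbers stand for less inhibition and higher numbers for more inhibition at the one concentration tested (going by the name of the read-out):
- compound 1 `c1ccc(-c2cn3ccnc3c(-c3ccc4ncn(C5CCCCC5)c4c3)n2)cc1`: 22.9%
- compound 2 `O=Cc1ccc(-c2cn3ccnc3c(-c3ccc4ncn(C5CCCCC5)c4c3)n2)cc1`: 14.4%
- compound 3 `Clc1ccc(-c2cn3ccnc3c(-c3ccc4ncn(C5CCCCC5)c4c3)n2)cc1`: 15.8%

Compound 3 sits second highest of the three numbers in this assay. Its nearest neighbour is compound 2, at a number 1.4 percentage points higher from compound 2 to compound 3 (within the scatter), and its furthest is compound 1, at a number 7.1 percentage points lower from compound 1 to compound 3 (within the scatter); both steps lie within the scatter, so the three compounds cannot be ordered on these data.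

Compound 4 `Brc1ccc(-c2cn3ccnc3c(-c3ccc4ncn(C5CCCCC5)c4c3)n2)cc1` is the next step. It differs from compound 3 in one place: bromo in place of chloro on an aromatic carbon.

Among the measured compounds shown here, no measured step changes one halogen for another, so none bears directly on this move. What is on hand is that the chloro substituent gave a number 7.1 percentage points lower from compound 1 to compound 3 (within the scatter) and the formyl substituent gave a number 8.5 percentage points lower from compound 1 to compound 2 (within the scatter), both within the scatter, and the swap of formyl for chloro gave a number 1.4 percentage points higher from compound 2 to compound 3 (within the scatter). Substituents on this phenyl ring have so far shifted the read-out by nothing beyond the scatter; the chloro-to-bromo change is expected to behave the same way, with no step beyond the scatter in this assay, so a number 1.2 percentage points higher from compound 3 to compound 4 (within the scatter) is the expected step.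

Compound 4 is therefore estimated at 17% in this assay, with a range from 5% to 30%.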

Compound 4, a percentage reported as inhibition, at one concentration (the size of the read-out at that concentration, not a potency): 18.3%
Compound 4: middle estimate off by 1.3 percentage points, on the low side; measured number inside the range.
By their numbers in this assay, from the lowest: compounds 2, 3, 4 and 1 (each within the scatter of the next).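

In this assay, among the compounds shown here, the 4-chlorophenyl to 4-bromophenyl change provides the first direct halogen-for-halogen comparison at this aromatic carbon, and the step stays within the scatter (a number 2.5 percentage points higher from compound 3 to compound 4 (within the scatter)), so these two halogens cannot be told apart on this read-out. Bromo also stays within the scatter when set against formyl (a number 3.9 percentage points higher from compound 2 to compound 4 (within the scatter)) and against hydrogen (a number 4.6 percentage points lower from compound 1 to compound 4 (within the scatter)), which extends the flat picture at this position to four groups, none of which can be ordered against the others on these numbers. No supporting data are available that could explain this result or any of the steps around it.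

Whether an amine, a carboxylic acid, a methoxy group or a longer chain on this same carbon would produce a step beyond the scatter remains open, since the groups shown are limited to hydrogen, formyl, chloro and bromo. Also open, on these data alone, are how changes elsewhere on the shared core would register, and how these compounds would compare in a full concentration series rather than at the single concentration used here.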